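The source may hold more compounds than are shown below. What is called first, only, known or untested is meant among the compounds shown, and "the series" means these compounds.

In an assay for inhibition of histone-lysine N-methyltransferase, H3 lysine-79 specific (Homo sapiens), read by scintillation counting, with stated times of 15 min and 60 min, tested at 100 uM, in the presence of a further agent that is not named here (on this read-out higher numbers stand for a stronger effect at the one concentration tested and lower numbers for a weaker effect), compound 2 `Cc1cccc(-c2nnc3sc(/C=C/c4ccco4)nn23)c1` gives 74%, the higher of the two numbers measured, while compound 1 `Fc1ccc(-c2nnc3sc(/C=C/c4ccco4)nn23)cc1` gives 40%. Going by the values given here, the single measured step, a number 34 percentage points higher from compound 1 to compound 2 (beyond the scatter), shows that a change of the group on this aromatic carbon can shift the read-out strongly. Compound 3 `C(=C/c1nn2c(C3CCCCC3)nnc2s1)\c1ccco1` differs from compound 2 by cyclohexyl in place of 3-methylphenyl on an aromatic carbon. Because that one step, a number 34 percentage points higher from compound 1 to compound 2 (beyond the scatter), came from a change at the same place, a step beyond the scatter is expected here too, though its direction cannot be read from a single comparison. Compound 3 is therefore estimated at 55%, within 25% to 85%. That estimate means a step of a number 19 percentage points lower from compound 2 to compound 3 (beyond the scatter).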

Compound 3, a percentage reported as inhibition, at one concentration (the size of the read-out at that concentration, not a potency): 72%
The estimate for compound 3 lay 17 percentage points below the measured number; the measured number falls inside the stated range.
By their numbers in this assay, from the lowest: compound 1; then compounds 3 and 2 (each within the scatter of the next).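

In this assay cyclohexyl in place of 3-methylphenyl gives a number 2 percentage points lower from compound 2 to compound 3 (within the scatter) and so shows that a six-membered aromatic ring is not needed on this carbon for a high read-out. Cyclohexyl in place of 4-fluorophenyl gives a number 32 percentage points higher from compound 1 to compound 3 (beyond the scatter) and so leaves compound 1 alone at the low end, with the aromatic ring of compound 2 going against any rule that aromatic groups here give low numbers. Nothing given here explains these numbers. Still open, on these data alone, is how a group without a carbon ring, such as an amine, a carboxylic acid or a longer chain, would behave on this carbon.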